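The source may report more compounds than this note shows. Statements on the series, on what has been measured and on what is new or still open speak of the compounds shown alone.

In an ADME assay on J774 cells (Mus musculus) for cytotoxicity (a lower number here means that less compound is needed, a higher number that more compound is needed for the effect), the starting point is compound 2 (`CCCCc1cc2c(=O)c(C(=O)OC)c[nH]c2cc1OCCOc1ccccc1`). Compound 2 gives > 20000 nM and this is a limit, not a number. Compound 1 (`CCCCc1cc2c(=O)c(C(=O)OCC)c[nH]c2cc1OCCOc1ccccc1`) gives > 20000 nM and this too is a limit. Compound 3 (`CCc1cc2c(=O)c(C(=O)OC)c[nH]c2cc1OCCOc1ccccc1`) gives > 20000 nM and this is also a limit. Among the measured compounds shown here, the picture so far is therefore the limit of > 20000 nM in this assay, at which 3 of the 3 values shown sit, and no compound has yet given a true number.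

Two measured steps lie close to the next change (a step that the two limits leave unreadable from compound 1 to compound 2 and a step that the two limits leave unreadable from compound 2 to compound 3) and neither has a size that can be carried over.

Compound 4 (`CCCCc1cc2c(=O)c(C(=O)NCC)c[nH]c2cc1OCCOc1ccccc1`) carries ethylamino in place of methoxy on a carbonyl carbon of compound 2 (ethylamino in place of methoxy on a carbonyl carbon) so that methoxycarbonyl becomes ethylcarbamoyl. For the measured compounds named here, none of the measured compounds carries ethylcarbamoyl, and limits alone give neither a size nor a direction. In this assay no step beyond the scatter is therefore expected, and another limit is the most likely report. The expected result is a step that the limit leaves unreadable from compound 2 to compound 4 without a firm direction. Compound 4 is estimated at 25000 nM with an expected range from 10000 nM to 50000 nM if a number is reported at all.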

Compound 4, half-maximal effective concentration: > 20000 nM
Compound 4 gave a limit, no number (the forecaster's own chance of this, stated with the estimate: 85%); the middle value lies beyond the limit too.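

In this assay compound 4 gives > 20000 nM and this is a limit, not a number. Its steps from compound 1 and from compound 2 therefore cannot be read. The compounds shown leave open what effect, if any, ethylamino in place of methoxy has in this assay, with every result at one limit: the limit of > 20000 nM in this assay, at which 4 of the 4 values shown sit.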